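The source may hold more compounds than are shown below. What is called first, only, known or untested is meant among the compounds shown, and "the series" means these compounds.

Among the compounds with values here, compound 1, with the structure `O=C(NC(=S)Nc1nc2cc(Br)ccc2s1)c1ccccc1`, is one of three compounds measured in a functional assay on MCF7 cells (Homo sapiens) for cytotoxicity, read by MTT assay, with a stated time of 24 h; on this read-out higher numbers stand for weaker inhibition and lower numbers for stronger inhibition. In this assay compound 1 gives 32100 nM. Compound 2, `O=C(NC(=S)Nc1nc2cc(Br)ccc2s1)c1ccc([N+](=O)[O-])cc1`, gives 32400 nM, and compound 3, `O=C(NC(=S)Nc1nc2ccccc2s1)c1ccccc1`, gives 37300 nM. Compound 1 has the lowest of the three numbers, but the two steps that connect it to the others, a 1.0-fold higher number from compound 1 to compound 2 (0.00 log units; within the scatter) and a 1.2-fold higher number from compound 1 to compound 3 (0.07 log units; within the scatter), both lie within the usual scatter, so the three compounds cannot be told apart on these numbers.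

Compound 4, `O=C(NC(=S)Nc1nc2cc(Br)ccc2s1)N1CCOCC1`, is not yet measured. It differs from compound 1 in one place: morpholin-4-yl in place of phenyl on a carbonyl carbon. Neither measured step bears directly on this change, since both of them touch the aromatic ring of the shared core rather than the carbonyl carbon. Within the data shown here, all the measured steps were small, and nothing here shows what exchanging a phenyl for a morpholin-4-yl does. The expectation for compound 4 is therefore a step of about a 1.1-fold higher number from compound 1 to compound 4 (0.04 log units; within the scatter), that is no shift beyond the scatter, with a wide range. Compound 4 is estimated to give 35000 nM in this assay, expected to fall between 14000 nM and 90000 nM.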

Compound 4, half-maximal inhibitory concentration: 18100 nM
Beside the measured number, compound 4's estimate is 1.9-fold (0.29 log units) above it; low and high end bracket the measured number.
By their numbers in this assay, from the lowest: compounds 4, 1, 2 and 3 (each within the scatter of the next, the first and the last beyond it).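

Within the data shown here, this is the first change at the carbonyl carbon, since the earlier steps touched only the aromatic ring of the shared core. In this assay, replacing phenyl with morpholin-4-yl at this position gives a 1.8-fold lower number from compound 1 to compound 4 (0.25 log units; within the scatter), so an aromatic ring of carbon only can give way to a non-aromatic ring containing hetero atoms without a shift beyond the scatter. No measurement available here explains this result.

On these data alone, it remains open whether a piperidin-1-yl ring, an open-chain dimethylamino group or a longer alkyl chain on the same carbonyl carbon would move the number beyond the scatter, which would show how much this position can tolerate. As far as these compounds go, it is also open whether morpholin-4-yl would give a similar result on the core that carries hydrogen in place of bromo, as in compound 3, since a single exchange on a single core cannot show whether the two positions act independently.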